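The source may report more compounds than this note shows. Statements on the series, on what has been measured and on what is new or still open speak of the compounds shown alone.

Measured compounds in a functional assay on the whole organism (strain A/J) for inhibition, with Mus musculus as the target, with stated times of 1 h and 18 h, at a dose of 100 umol/kg by the oral route; on this read-out lower numbers stand for less inhibition and higher numbers for more inhibition at the one dose given (going by the name of the read-out):

- compound 1, `COc1ccc(/C=N/N(C)C(=O)c2ccccc2OC)cc1OC`; compound 1 gives 59%
- compound 2, `COc1ccc(C(=O)N(C)/N=C/c2ccc(OC)c(OC)c2)cc1`; compound 2 gives 62%

For the measured compounds named here, compound 2 holds the higher of the two numbers, but its only neighbour, compound 1, sits a step of a number 3 percentage points higher from compound 1 to compound 2 (within the scatter) away, so the two are not separated on this read-out.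

Compound 3, `COc1ccc(/C=N/N(C)C(=O)c2ccccc2)cc1OC`, is not yet measured. It differs from compound 2 by hydrogen in place of methoxy on an aromatic carbon. Going by the values given here, no measured step removes a methoxy group; the one measured step, a number 3 percentage points higher from compound 1 to compound 2 (within the scatter), moves the methoxy from one place on the carbonyl-side ring to another and stays within the scatter. Going by these compounds, that step suggests the carbonyl-side methoxy carries little weight, but whether its loss costs anything is untested.

The expectation for compound 3 is therefore a step of about a number 7 percentage points lower from compound 2 to compound 3 (within the scatter), not beyond the scatter. Compound 3 is estimated at 55%, in a range of 35% to 72%.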

Compound 3, a percentage reported as inhibition, in the whole organism at one dose (the size of the read-out at that dose, not a potency): 51%
Compound 3: middle estimate off by 4 percentage points, on the high side; measured number inside the range.
By their numbers in this assay, from the lowest: compounds 3, 1 and 2 (each within the scatter of the next, the first and the last beyond it).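

In this assay, for the compounds shown here, the step of a number 11 percentage points lower from compound 2 to compound 3 (beyond the scatter) is the first in this set to lie beyond the scatter, so the change from 4-methoxyphenyl to phenyl, at the place para to a large group, does register, if modestly. Removing the methoxy from its place in compound 1 gives a step that stays within the scatter, a number 8 percentage points lower from compound 1 to compound 3 (within the scatter), so only the loss of the methoxy in compound 2 separates from the unsubstituted ring. No data here give a reason for this difference between the two methoxy placements.

Going by these compounds, whether an amine or a carboxylic acid at the para place would keep the number near that of compound 2 remains open. The compounds shown also leave open what the two methoxy groups on the other ring and the methyl on the nitrogen contribute, since both are constant across the series.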